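This account rests on a few compounds, and the source may have more. Where it says the series, first, only, none or still open, it means among the compounds named here.

Measured to date:
- compound 1 `CC(C)OC(=O)N1CCC(Oc2ncnc3c2CCN3c2ccc(S(C)(=O)=O)cc2F)CC1` gives 50.1 nM in a functional assay on CHO-K1 cells for agonist activity at Glucose-dependent insulinotropic receptor (Homo sapiens), read by a luciferase reporter, with a stated time of 5 h; on this read-out higher numbers stand for an effect only at larger amounts of compound and lower numbers for an effect already at smaller amounts
- compound 2 `Cc1nc(OC2CCN(C(=O)OC(C)C)CC2)c2c(n1)N(c1ccc(S(C)(=O)=O)cc1F)CC2` gives 100 nM
- compound 3 `CC(C)OC(=O)N1CCC(Oc2nc(N)nc3c2CCN3c2ccc(S(C)(=O)=O)cc2F)CC1` gives 794 nM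

Compound 3 stands with the highest number of the three, with a 16-fold higher number from compound 1 to compound 3 (1.20 log units; beyond the scatter) and a 7.9-fold higher number from compound 2 to compound 3 (0.90 log units; beyond the scatter), whereas a 2.0-fold higher number from compound 1 to compound 2 (0.30 log units; within the scatter) stays within the scatter. Compound 4 `CNc1nc(OC2CCN(C(=O)OC(C)C)CC2)c2c(n1)N(c1ccc(S(C)(=O)=O)cc1F)CC2` carries the change (methyl in place of hydrogen on a nitrogen on an aromatic ring); cut one bond further out it reads amino to methylamino. For the measured compounds named here, no measured pair alters a substituent on that nitrogen, so neither step bears directly on it. Going by the values given here, the two steps introducing the amino group are the only related information. The number for compound 4 is therefore expected near that of compound 3, with a 1.3-fold lower number from compound 3 to compound 4 (0.10 log units; within the scatter) as the estimated step. Compound 4 is estimated at 630 nM, within 200 nM to 2000 nM.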

Compound 4, half-maximal effective concentration: > 10000 nM
Compound 4 was reported as a limit; the forecaster's own chance of this, stated with the estimate: 5%; middle value at least 15-fold (1.20 log units) away from the limit.
By their numbers in this assay, from the lowest: compounds 1 and 2 (each within the scatter of the next); then compound 3. At a limit, above all of these: compound 4.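

Compound 4 is reported only as a limit, not as a number: the limit of > 10000 nM in this assay, at which 1 of the 4 values shown sits.

On the amino group, methyl in place of hydrogen on a nitrogen on an aromatic ring is not a minor edit, giving an at least 12-fold higher number from compound 3 to compound 4 (1.10 log units; beyond the scatter). Against the smaller groups on that aromatic carbon, methylamino stands far apart, with an at least 100-fold higher number from compound 2 to compound 4 (2.00 log units; beyond the scatter) and an at least 190-fold higher number from compound 1 to compound 4 (2.30 log units; beyond the scatter).

As far as these compounds go, whether dimethylamino, ethylamino or methoxy on that carbon would follow methylamino or stay nearer to methyl remains open. How far the true number for compound 4 lies past its limit is also unknown.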